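Cytotoxicity notes: aryl variation para to the amide carbonyl

The compounds below may be only part of what the source reports. "The series", "measured", "known", "first", "only" and "open" are said of these compounds alone.

The series shares a core carrying an isopropyl-amide and an ethyl ester chain, varied only in the aryl group. Compound 1 `CCOC(=O)CCCCCOc1cccc(CN(C(=O)c2ccc(-c3cccc(NC(C)=O)c3)cc2)C(C)C)c1`, compound 2 `CCOC(=O)CCCCCOc1cccc(CN(C(=O)c2ccc(-c3cnc(OC)nc3OC)cc2)C(C)C)c1` and compound 3 `CCOC(=O)CCCCCOc1cccc(CN(C(=O)c2ccc(-c3ccc4[nH]ccc4c3)cc2)C(C)C)c1` have all been tested in an ADME assay on HepG2 cells (Homo sapiens) for cytotoxicity, read by CellTiter-Glo and resazurin assay, with a stated time of 72 h; a lower number here means that less compound is needed, a higher number that more compound is needed for the effect. In this assay compound 1 gives a limit, > 26000 nM. In this assay compound 2 likewise gives a limit, > 26000 nM. In this assay compound 3 also gives only a limit, > 26000 nM. Because of the limit of > 26000 nM in this assay, at which 3 of the 3 values shown sit, the steps a step that the two limits leave unreadable from compound 1 to compound 2, a step that the two limits leave unreadable from compound 1 to compound 3 and a step that the two limits leave unreadable from compound 2 to compound 3 cannot be sized; compound 3 therefore stands with the other two, at the limit.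

Compound 4 `CCOC(=O)CCCCCOc1cccc(CN(C(=O)c2ccc(-c3cccc(OC(F)(F)F)c3)cc2)C(C)C)c1` differs from compound 3 by 3-(trifluoromethoxy)phenyl in place of 1H-indol-5-yl on an aromatic carbon. Within the data shown here, none of the measured steps gives a readable size, so there is no basis for expecting a shift beyond the scatter in this assay, in either direction. The expected step is a step that the limit leaves unreadable from compound 3 to compound 4. Compound 4 is expected to give about 30000 nM, within a range of 15000 nM to 80000 nM, most likely again reported as a limit.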

Compound 4, half-maximal effective concentration: > 26000 nM
Compound 4 was reported as a limit; the forecaster's own chance of this, stated with the estimate: 80%; the middle value is on the limit's open side.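

Compound 4 sits at a limit in this assay, as do compound 1, compound 2 and compound 3, so none of the steps to compound 4 can be read: the limit of > 26000 nM in this assay, at which 4 of the 4 values shown sit.

The compounds shown leave open whether the aryl group affects cytotoxicity at all, and at what concentration any of them would produce the effect.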